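Vinyl to 2-phenylethenyl on the sulfonyl of compound 2

The source may report more compounds than this note shows. Statements on the series, on what has been measured and on what is new or still open speak of the compounds shown alone.

In a functional assay on MDA-MB-231 cells (Homo sapiens) for antiproliferative activity, read by MTT assay, with a stated time of 48 h (on this read-out lower numbers stand for stronger inhibition and higher numbers for weaker inhibition), three compounds on a shared core have measured values. Compound 1 `C=CS(=O)(=O)N1CCN(c2ncnc3sc(-c4ccc(C(F)(F)F)cc4)cc23)CC1` gives 6410 nM, compound 2 `C=CS(=O)(=O)N1CCN(c2ncnc3sc(-c4ccc(N5CCN(C)CC5)cc4)cc23)CC1` gives 7550 nM, and compound 3 `C=CS(=O)(=O)N1CCN(c2nc(OC[C@H]3CCCN3C)nc3sc(-c4ccc(N5CCN(C)CC5)cc4)cc23)CC1` gives 760 nM. Compound 2 therefore stands at the upper end of these numbers, alongside compound 1.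

Compound 4 `CN1CCN(c2ccc(-c3cc4c(N5CCN(S(=O)(=O)/C=C/c6ccccc6)CC5)ncnc4s3)cc2)CC1` is the next to be read. It carries one change relative to compound 2: 2-phenylethenyl in place of vinyl on a sulfonyl sulfur.

Two measured steps give context. Exchanging trifluoromethyl for 4-methylpiperazin-1-yl gives a 1.2-fold higher number from compound 1 to compound 2 (0.07 log units; within the scatter), within the scatter. Adding (1-methylpyrrolidin-2-yl)methoxy gives a 9.9-fold lower number from compound 2 to compound 3 (1.00 log units; beyond the scatter), beyond the scatter. Among the measured compounds shown here, neither step touches the sulfonyl sulfur, so the data hold no direct precedent for this change and give no firm direction. The measured value of compound 2, 7550 nM, is the only anchor, and no step beyond the scatter is expected in this assay.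

The estimated step is small: a 1.2-fold higher number from compound 2 to compound 4 (0.08 log units; within the scatter). Compound 4 is expected at 9000 nM, with an estimated range of 3500 nM to 25000 nM.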

Compound 4, half-maximal inhibitory concentration: 5900 nM
Compound 4: the middle estimate sits 1.5-fold (0.18 log units) above what was measured; the range from low to high includes it.
By their numbers in this assay, from the lowest: compound 3; then compounds 4, 1 and 2 (each within the scatter of the next).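

In this assay, among the compounds shown here, the pair of compound 2 and compound 4 gives the only reading at the sulfonyl sulfur, whose other neighbour is a sulfonamide nitrogen in a ring: 2-phenylethenyl in place of vinyl gives a 1.3-fold lower number from compound 2 to compound 4 (0.11 log units; within the scatter). The entering group adds a six-membered aromatic ring of carbon only and keeps the double bond outside aromatic rings, yet this read-out does not separate compound 4 from compound 2, so at this position, in this one pair, the larger group leaves the antiproliferative read-out within the usual scatter. No measurement is available that would explain this result or link it to any property of either group.

Open, on these data alone, is whether the double bond on the sulfonyl sulfur matters at all, since a saturated ethyl or a plain methyl group there, or an amine or carboxylic acid on the phenyl ring of 2-phenylethenyl, would test this directly. For the compounds shown here, also open is whether the same exchange reads alike on the background of compound 3, which carries (1-methylpyrrolidin-2-yl)methoxy and gives 760 nM in this assay, as the one pair here speaks only for the unsubstituted background of compound 2.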